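Swapping one methyl for fluoro on a weak compound

A few compounds are considered here, and "the series" means these few. Any claim that something is new, unique, unknown or untested is made for them only; others in the source may bear on it.

Measured in a functional assay on U-251 cells (Homo sapiens) for cytotoxicity; on this read-out lower numbers stand for stronger inhibition of growth and higher numbers for weaker inhibition of growth:
- compound 1 `COc1ccc(C2=C(c3ccc(SC)cc3)CC3CCCN3C2=O)cc1Br`: 800 nM
- compound 2 `COc1ccc(C2=C(c3ccc(SC)cc3)CC3CCCN3C2=O)cc1C`: 90 nM
- compound 3 `CSc1ccc(C2=C(c3ccc(C)c(C)c3)C(=O)N3CCCC3C2)cc1`: 10000 nM

Of these three, compound 3 has the highest number and so the weakest growth inhibition. The next compound, compound 4 `CSc1ccc(C2=C(c3ccc(F)c(C)c3)C(=O)N3CCCC3C2)cc1`, carries fluoro in place of methyl on an aromatic carbon. That methyl is the group that took the place of methoxy in the largest measured step, a 110-fold higher number from compound 2 to compound 3 (2.05 log units; beyond the scatter). The swap of bromo for methyl on the same ring gave an 8.9-fold lower number from compound 1 to compound 2 (0.95 log units; beyond the scatter), so single swaps here can matter. Going by the values given here, no measured step involves fluoro, so only a modest change is expected, towards a lower number. The expected result is a 2.5-fold lower number from compound 3 to compound 4 (0.40 log units; beyond the scatter). Compound 4 is estimated at 4000 nM, with an expected range from 1000 nM to 15000 nM.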

Compound 4, concentration for 50% growth inhibition: 200 nM
Compound 4: the middle estimate sits 20-fold (1.30 log units) above what was measured, outside the stated range (below it).
By their numbers in this assay, from the lowest: compound 2; then compound 4; then compound 1; then compound 3.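

At this position this assay responds strongly to one small group: fluoro in place of methyl gives a 50-fold lower number from compound 3 to compound 4 (1.70 log units; beyond the scatter) and so recovers most of the ground lost with methyl. Fluoro in place of methoxy gives a 2.2-fold higher number from compound 2 to compound 4 (0.35 log units; beyond the scatter) and so does not quite match methoxy, while 4-fluoro-3-methylphenyl in place of 3-bromo-4-methoxyphenyl gives a 4.0-fold lower number from compound 1 to compound 4 (0.60 log units; beyond the scatter) and shows the fluoro compound ahead of the bromo one. Going by these compounds, whether an amine or a hydroxyl group here would equal methoxy stays open. No measured evidence shows why such small swaps matter so much at this position.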